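Notes on the N-aryl change in the series

The compounds below may be only part of what the source reports. "The series", "measured", "known", "first", "only" and "open" are said of these compounds alone.

Measured so far:
- Compound 1 `COc1cc2c(Oc3ccc(NC(=O)c4nn(-c5ccccc5OC(F)(F)F)c(=O)cc4C)cc3F)ccnc2cc1OCCCN1CCCCC1` gives 190 nM in a functional assay on HT-29 cells (Homo sapiens) for inhibition, read by MTT assay, with a stated time of 72 h; on this read-out higher numbers stand for weaker inhibition and lower numbers for stronger inhibition
- Compound 2 `COc1cc2c(Oc3ccc(NC(=O)c4nn(-c5ccccc5OC(F)(F)F)c(=O)cc4C)cc3F)ccnc2cc1OCCCN1CCN(C)CC1` gives 180 nM in this assay

Compound 2 holds the lowest of the two numbers in this assay, with compound 1 the nearest, and the two lie within the scatter of each other, as the step of a 1.1-fold lower number from compound 1 to compound 2 (0.02 log units; within the scatter) shows. Within the data shown here, that single step alters the chain amine only, so no measured step touches the part of the molecule changed next.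

Compound 3 `COc1ccc(-n2nc(C(=O)Nc3ccc(Oc4ccnc5cc(OCCCN6CCN(C)CC6)c(OC)cc45)c(F)c3)c(C)cc2=O)cc1` differs from compound 2 in one place: 4-methoxyphenyl in place of 2-(trifluoromethoxy)phenyl on an aromatic nitrogen, next to the ring nitrogen, ortho to a group of 1 heavy atom, meta to a large group, para to a methyl group. Among the measured compounds shown here, no measured pair bears on this exchange, so the direction cannot be read from the data; the expectation is a number near compound 2, with wide uncertainty. For compound 3 the step of a 1.4-fold higher number from compound 2 to compound 3 (0.14 log units; within the scatter) is expected, giving an estimate of 250 nM with a range of 80 nM to 800 nM.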

Compound 3, half-maximal inhibitory concentration: 3520 nM
For compound 3 the middle estimate is 14-fold (1.15 log units) below the measured one; measured number above the stated range.
By their numbers in this assay, from the lowest: compounds 2 and 1 (each within the scatter of the next); then compound 3.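

In this assay, among these compounds, putting 4-methoxyphenyl in place of 2-(trifluoromethoxy)phenyl on the aromatic nitrogen gives a 20-fold higher number from compound 2 to compound 3 (1.29 log units; beyond the scatter), so this position can shift the number well beyond the scatter, whereas the one earlier step, at the chain amine, stayed within it. On this single pair, the group on the aromatic nitrogen therefore matters far more than the exchange of piperidin-1-yl for 4-methylpiperazin-1-yl. No measurement at hand bears on what lies behind the weaker inhibition of compound 3.

The exchange alters both the substituent and its place on the phenyl ring, and this pair cannot separate the two. Going by these compounds, a comparison with 2-methoxyphenyl, 4-(trifluoromethoxy)phenyl or unsubstituted phenyl on the same nitrogen would bear on this, and the answer remains open.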